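Bromo to trifluoromethyl swap on the aryl ether tail

The source may report more compounds than this note shows. Statements on the series, on what has been measured and on what is new or still open speak of the compounds shown alone.

Measured in a functional assay on cells (Homo sapiens) for cytotoxicity; a lower number here means that less compound is tolerated, a higher number that more compound is tolerated:
compound 1 `O=C1N(CCCCCCCOc2ccc(C(F)(F)F)cc2)CCN1c1ccncc1`: 6250 nM
compound 2 `O=C1N(CCCCCCCOc2ccc(Br)cc2)CCN1c1ccncc1`: > 25000 nM, a limit of the assay, not a number
compound 3 `O=C1N(CCCCCCOc2ccc(Br)cc2)CCN1c1ccnc(Cl)c1`: > 25000 nM, a limit of the assay, not a number

Compound 1 and compound 2 share one core and differ only at the aryl ether end: trifluoromethyl in place of bromo on an aromatic carbon. That change gave an at least 4.0-fold lower number from compound 2 to compound 1 (0.60 log units; beyond the scatter). The step can only be stated as a lower bound because of the limit of > 25000 nM in this assay, at which 2 of the 3 values shown sit. Compound 3 sits on another core; the difference between the two cores is not broken down here. For compound 3 only a limit in this assay is known.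

Compound 4 `O=C1N(CCCCCCOc2ccc(C(F)(F)F)cc2)CCN1c1ccnc(Cl)c1` is not yet measured in this assay. It stands to compound 3 as compound 1 stands to compound 2, the same change at the same place: trifluoromethyl in place of bromo on an aromatic carbon. The expectation is a step of about an at least 3.1-fold lower number from compound 3 to compound 4 (0.49 log units; beyond the scatter), resting on an at least 4.0-fold lower number from compound 2 to compound 1 (0.60 log units; beyond the scatter), with the caveat that compound 3 is itself only a limit, so the true gap may be smaller. Compound 4 is thus estimated at 8000 nM, expected between 2500 nM and 25000 nM.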

Compound 4, half-maximal cytotoxic concentration: > 25000 nM
Compound 4: no number, only a limit; the forecaster's own chance of this, stated with the estimate: 35%; at least 3.1-fold (0.49 log units) between middle value and limit.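

Compound 3 and compound 4 both sit at a limit rather than a number in this assay, so no step can be read for trifluoromethyl in place of bromo on this core: the limit of > 25000 nM in this assay, at which 3 of the 4 values shown sit.

Still open, as far as these compounds go, is whether that change lowers the number on the core of compound 3 as it does on the core of compound 1.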